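The compounds below may be only part of what the source reports. "The series", "measured", "known", "first", "only" and "open" are said of these compounds alone.

Measured in a functional assay on HCT-116 cells (Homo sapiens) for antiproliferative activity, read by MTT assay, with a stated time of 48 h; on this read-out higher numbers stand for weaker inhibition and lower numbers for stronger inhibition:
- compound 1 `COc1ccc(CN(C(=O)CSc2nc3ccccc3s2)c2cc(OC)c(OC)c(OC)c2)cc1[N+](=O)[O-]`: 1280 nM
- compound 2 `COc1cc(N(Cc2ccccc2)C(=O)CSc2nc3ccccc3s2)cc(OC)c1OC`: 54500 nM

Compound 2 has the higher number of the two, so it is the weaker inhibitor. Among the compounds with values here, the only measured step is a 43-fold higher number from compound 1 to compound 2 (1.63 log units; beyond the scatter), and it exchanged 4-methoxy-3-nitrophenyl for phenyl. Compound 3 `COc1cc(N(Cc2ccc(F)cc2)C(=O)CSc2nc3ccccc3s2)cc(OC)c1OC` changes that same phenyl, with fluoro in place of hydrogen on an aromatic carbon, para to a large group: fluoro in place of hydrogen on an aromatic carbon. This exchange is much smaller, so a far smaller move toward a lower number in this assay is expected, perhaps not beyond the scatter. The estimated step is a 1.8-fold lower number from compound 2 to compound 3 (0.26 log units; within the scatter). For compound 3 the estimate is 30000 nM, with an expected range from 9000 nM to 70000 nM.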

Compound 3, half-maximal inhibitory concentration: 59800 nM
Compound 3: the middle estimate sits 2.0-fold (0.30 log units) below what was measured, and the stated range covers the measured number.
By their numbers in this assay, from the lowest: compound 1; then compounds 2 and 3 (each within the scatter of the next).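

In this assay, fluoro in place of hydrogen gives a 1.1-fold higher number from compound 2 to compound 3 (0.04 log units; within the scatter), so compound 2 and compound 3 cannot be told apart at this position. Like phenyl, 4-fluorophenyl stays far from 4-methoxy-3-nitrophenyl, with a 47-fold higher number from compound 1 to compound 3 (1.67 log units; beyond the scatter) in the same direction as the earlier step. No measurement here offers a reason for this result. The compounds shown leave open whether the methoxy or the nitro group of compound 1 matters more, as neither stands alone on this ring. They also leave open how an amine or a hydroxyl group would behave there.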